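Sigma-1 binding: benzyl to fluorophenylcarbonyl on the chain

This account rests on a few compounds, and the source may have more. Where it says the series, first, only, none or still open, it means among the compounds named here.

Compound 1, `OC1CN(CCCCc2ccccc2)CCc2cc(OCc3ccccc3)ccc21`: 293 nM
Compound 2, `CN(Cc1ccccc1)C(=O)CN1CCc2cc(OCc3ccccc3)ccc2C(O)C1`: > 1000 nM

For the measured compounds named here, in an assay for displacement of a labelled ligand from Sigma non-opioid intracellular receptor 1 (Cavia porcellus), read by scintillation counting, with a stated time of 180 min (on this read-out higher numbers stand for weaker inhibition and lower numbers for stronger inhibition), compound 1 gives 293 nM, the only number measured in this small set. Compound 2 gives only > 1000 nM, which is a limit of the assay and not a number, and so sits at the limit of > 1000 nM in this assay, at which 1 of the 2 values shown sits. Compound 3, `O=C(CCCN1CCc2cc(OCc3ccccc3)ccc2C(O)C1)c1ccc(F)cc1`, differs from compound 1 by (4-fluorophenyl)carbonyl in place of benzyl on a saturated chain carbon, three bonds along the chain from an amine nitrogen in a ring. Going by the values given here, no measured step isolates a single change, so the size of this one is open. The step expected here, a 2.9-fold lower number from compound 1 to compound 3 (0.47 log units; beyond the scatter), runs toward stronger inhibition and beyond the usual scatter. The estimated value for compound 3 in this assay is 100 nM, with a range from 25 nM to 400 nM.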

Compound 3, inhibition constant: 293 nM
Compound 3: the middle estimate sits 2.9-fold (0.47 log units) below what was measured, and the stated range covers the measured number.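

In this assay, for the compounds shown here, (4-fluorophenyl)carbonyl in place of benzyl on a saturated chain carbon, three bonds along the chain from an amine nitrogen in a ring, gives no change at the digits printed from compound 1 to compound 3 (within the scatter), the first step that can be read at this position. The position therefore accepts a carbonyl and a fluorine together without a readable shift in binding. Nothing measured here gives a cause for this result. The carbonyl and the fluorine enter together, so the effect of each alone stays unread. Going by these compounds, whether the aromatic ring is needed here also stays open, and an amine, a carboxylic acid or a longer chain at this place would test that.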